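A few compounds are considered here, and "the series" means these few. Any claim that something is new, unique, unknown or untested is made for them only; others in the source may bear on it.

Measured compounds in an ADME assay on the whole organism with Oryza sativa as the target, tested at 0.1 uM; a higher number here means a weaker effect of the compound at the concentration tested, a lower number a stronger effect:
- compound 1, `CCCCCCc1ccc(NC(=O)N[C@@H](C)c2ccccc2)cc1`: 99%
- compound 2, `C[C@H](NC(=O)Nc1ccc(Br)cc1)c1ccccc1`: 98%

For the measured compounds named here, compound 2 stands in this assay at a number that is within the scatter of the only other measured compound, compound 1, so the two cannot be told apart on these data. Going by the values given here, the one measured step, a number 1 percentage points lower from compound 1 to compound 2 (within the scatter), exchanges one group on an aromatic carbon for another and moves the read-out within the scatter.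

Compound 3, `C[C@H](NC(=O)Nc1ccc(I)cc1)c1ccccc1`, has not yet been measured in this assay. It differs from compound 2 by iodo in place of bromo on an aromatic carbon. Among the compounds with values here, no measured pair shows this exact exchange; the nearest comparison is the step from compound 1 to compound 2, which also replaces one group at the same aromatic carbon and stayed within the scatter. On that basis he expects compound 3 to move by a number 1 percentage points lower from compound 2 to compound 3 (within the scatter) from compound 2, a step he expects to stay within the scatter. His estimate for compound 3 is 97%, with an expected range from 89% to 100%.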

Compound 3, a percentage reported as activity, at one concentration (the size of the read-out at that concentration, not a potency): 99%
The estimate for compound 3 lay 2 percentage points below the measured number; the measured number falls inside the stated range.
By their numbers in this assay, from the lowest: compounds 2, 1 and 3 (each within the scatter of the next).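

In this assay, iodo in place of bromo on an aromatic carbon, para to a large group, gives a number 1 percentage points higher from compound 2 to compound 3 (within the scatter), and iodo in place of hexyl at the same carbon gives no change at the digits printed from compound 1 to compound 3 (within the scatter). The earlier compounds shown here showed only that hexyl and bromo could not be told apart at this position; with iodo as a third group, and a second exchange of one halogen-bearing compound against the hexyl compound, all three now lie within the scatter of one another and no order among them can be drawn from these data. No independent measurement is available that would explain why these three groups cannot be told apart.

The compounds shown leave open whether a different kind of group at this position, such as an amine, a carboxylic acid or a hydroxyl, would move the read-out beyond the scatter. All the exchanges shown also sit at this one aromatic carbon, so whether a change elsewhere on the shared core would alter the number remains open as well.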